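A few compounds are considered here, and "the series" means these few. Any claim that something is new, unique, unknown or untested is made for them only; others in the source may bear on it.

Series notes. Compound 1 `O=C(c1cccc(Cl)c1)N1CCn2nc(-c3ccccn3)cc2C1` in a functional assay on HEK293 cells for negative allosteric modulation of metabotropic glutamate receptor 5 (Homo sapiens), read by calcium flux, with a stated time of 20 min (on this read-out lower numbers stand for stronger inhibition and higher numbers for weaker inhibition), gives 176 nM. Compound 2 `Cc1ccc(-c2cc3n(n2)CCN(C(=O)c2ccccc2)C3)nc1` gives 244 nM in this assay. Compound 3 `O=C(c1cccc(Cl)c1)N1CCn2nc(-c3ccc(F)cn3)cc2C1` gives 150 nM in this assay. Within the data shown here, the only single-point step measured so far, a 1.2-fold lower number from compound 1 to compound 3 (0.07 log units; within the scatter), brings fluoro onto the aromatic ring carried by the shared core. Compound 3 holds the lowest of the three numbers, but its gaps to compound 1 and to compound 2 both lie within the scatter, so no ordering among the three is drawn.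

Compound 4 `O=C(c1cccc(C(F)(F)F)c1)N1CCn2nc(-c3ccc(F)cn3)cc2C1` differs from compound 3 by trifluoromethyl in place of chloro on an aromatic carbon of a six-membered aromatic ring of carbon only, meta to a large group. Among the measured compounds shown here, no measured step touches this ring or this exchange; the step of a 1.2-fold lower number from compound 1 to compound 3 (0.07 log units; within the scatter) concerns the other aromatic ring and was itself within the scatter. With nothing bearing on the change, the expectation in this assay is a number close to that of compound 3, with no movement beyond the scatter in either direction. The expected step is a 1.1-fold higher number from compound 3 to compound 4 (0.03 log units; within the scatter). Compound 4 is estimated at 160 nM, with a range from 60 nM to 420 nM.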

Compound 4, half-maximal inhibitory concentration: 383 nM
Compound 4: the middle estimate sits 2.4-fold (0.38 log units) below what was measured; the range from low to high includes it.
By their numbers in this assay, from the lowest: compounds 3, 1, 2 and 4 (each within the scatter of the next, the first and the last beyond it).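

Among these compounds, the exchange of chloro for trifluoromethyl on the six-membered aromatic ring of carbon only, meta to a large group, gives the one step in this assay that lies beyond the scatter (a 2.6-fold higher number from compound 3 to compound 4 (0.41 log units; beyond the scatter)), though its size is modest. This shows that the number responds to a change at this place, which the fluoro step on the other aromatic ring (a 1.2-fold lower number from compound 1 to compound 3 (0.07 log units; within the scatter)) did not show, as that step stayed within the scatter. Of the two groups compared here on the shared core, chloro goes with the lower number, and nothing measured here accounts for the step.

As far as these compounds go, the exchange replaces one heavy atom with four and leaves the counts of donors and acceptors unchanged, so whether the step follows the number of heavy atoms or something else about trifluoromethyl stays open. From the compounds shown here alone, how a methyl, a methoxy, a nitrile or an amine would stand at this place is also open, as is the effect of hydrogen there, since compound 2 differs from compound 1 and compound 3 in more than one place.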